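This account rests on a few compounds, and the source may have more. Where it says the series, first, only, none or still open, it means among the compounds named here.

Of the compounds shown here, three built on one shared core have been measured in an ADME assay on 184B5 cells (Homo sapiens) for cytotoxicity, read by sulforhodamine B assay, with a stated time of 48 h; on this read-out lower numbers stand for stronger inhibition of growth and higher numbers for weaker inhibition of growth. Compound 1 `O=C1C(=O)N(CN2CCCCC2)c2cccc(Br)c21` gives 85200 nM. Compound 2 `CCN(CC)CN1C(=O)C(=O)c2c(Br)cccc21` gives 172000 nM, and compound 3 `O=C1C(=O)N(CN2CCCCC2)c2cccc(Cl)c21` gives 93700 nM. Among these three numbers compound 3 stands second highest, lying within the scatter of compound 1 and also within the scatter of compound 2. The move to compound 4 `CCN(CC)CN1C(=O)C(=O)c2c(Cl)cccc21` is diethylamino in place of piperidin-1-yl on a saturated chain carbon bound to an amide-type nitrogen in a ring. The same change has been seen once already, as a 2.0-fold higher number from compound 1 to compound 2 (0.31 log units; beyond the scatter), whereas a 1.1-fold higher number from compound 1 to compound 3 (0.04 log units; within the scatter) showed the halogen swap changing little. A comparable modest rise is therefore expected for compound 4, which would amount to a 2.0-fold higher number from compound 3 to compound 4 (0.30 log units; within the scatter). Compound 4 is accordingly estimated at 185000 nM, within a range from 100000 nM to 340000 nM.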

Compound 4, concentration for 50% growth inhibition: 22500 nM
The estimate for compound 4 lay 8.2-fold (0.91 log units) above the measured number; the whole stated range lies above it.
By their numbers in this assay, from the lowest: compound 4; then compounds 1, 3 and 2 (each within the scatter of the next, the first and the last beyond it).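

With chloro on the ring, diethylamino in place of piperidin-1-yl on a saturated chain carbon bound to an amide-type nitrogen in a ring gives a 4.2-fold lower number from compound 3 to compound 4 (0.62 log units; beyond the scatter), so this change has no fixed effect and reverses the direction seen with bromo: the same change on two cores in this assay, a 2.0-fold higher number (0.31 log units; beyond the scatter) from compound 1 to compound 2 and a 4.2-fold lower number (0.62 log units; beyond the scatter) from compound 3 to compound 4, 8.4-fold (0.92 log units) apart, beyond the scatter of two such steps. The halogen swap likewise depends on the amine, giving a 7.6-fold lower number from compound 2 to compound 4 (0.88 log units; beyond the scatter) with diethylamino after changing little with piperidin-1-yl: the same change on two cores in this assay, a 1.1-fold higher number (0.04 log units; within the scatter) from compound 1 to compound 3 and a 7.6-fold lower number (0.88 log units; beyond the scatter) from compound 2 to compound 4, 8.4-fold (0.92 log units) apart, beyond the scatter of two such steps. The two changes therefore do not add independently across these four compounds.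

As far as these compounds go, it remains open whether the fall is specific to this pairing of chloro and diethylamino. A morpholin-4-yl or dimethylamino group in the same place, or fluoro in place of chloro, would test how far it extends.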